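The source may report more compounds than this note shows. Statements on the series, on what has been measured and on what is new or still open speak of the compounds shown alone.

Measured compounds:
compound 1 `NC[C@@H]1CCCc2cc(S(=O)(=O)c3cccc(F)c3)ccc21`: 0.0794 nM
compound 2 `O=C1CN(C[C@@H]2CCCc3cc(S(=O)(=O)c4cccc(F)c4)ccc32)CCN1`: 6.31 nM

In an assay on isolated protein for displacement of a labelled ligand from 5-hydroxytryptamine receptor 6 (Homo sapiens) (on this read-out lower numbers stand for stronger inhibition and higher numbers for weaker inhibition), compound 1 gives 0.0794 nM, and compound 2 gives 6.31 nM. Compound 2 thus carries the higher of the two numbers shown, the weaker binding, and its only measured neighbour is compound 1, from which it differs by the step of a 79-fold higher number from compound 1 to compound 2 (1.90 log units; beyond the scatter).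

Compound 3 `NC(=O)CNC[C@@H]1CCCc2cc(S(=O)(=O)c3cccc(F)c3)ccc21` is the step onward: (carbamoylmethyl)amino in place of 3-oxopiperazin-1-yl on a saturated chain carbon bound to a saturated ring carbon. The ring of compound 2 is opened, and what remains is a chain bearing an amide, attached through a nitrogen that now carries a hydrogen again.

Among the compounds with values here, only the single step bears on this change, and it ran in one direction: adding the ring to the bare amine of compound 1 raised the number by a 79-fold higher number from compound 1 to compound 2 (1.90 log units; beyond the scatter). Compound 3 sits between the two in shape, keeping a donor on the nitrogen as compound 1 does while retaining an amide as compound 2 does. The expected step is therefore a lower number, a 6.3-fold lower number from compound 2 to compound 3 (0.80 log units; beyond the scatter), though of uncertain size. Compound 3 is estimated at 1 nM, with a range of 0.2 nM to 6 nM.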

Compound 3, inhibition constant: 0.1 nM
Estimate against measurement, compound 3: 10-fold (1.00 log units) above, and the stated range ends above it.
By their numbers in this assay, from the lowest: compounds 1 and 3 (each within the scatter of the next); then compound 2.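

Opening the ring brings the number back down in this assay by a large amount (a 63-fold lower number from compound 2 to compound 3 (1.80 log units; beyond the scatter)), so the weak binding of compound 2 does not follow from having an amide-bearing group at this place. Compared with the bare amine, adding carbamoylmethyl to the amine nitrogen makes no difference that can be told from the scatter (a 1.3-fold higher number from compound 1 to compound 3 (0.10 log units; within the scatter)), which shows that this nitrogen can carry that chain without a measurable cost in this assay. The drop seen with compound 2 is therefore tied to the 3-oxopiperazin-1-yl group as a whole, which differs from (carbamoylmethyl)amino in having a ring, more heavy atoms and one hydrogen-bond donor fewer, but no available measurement explains how any of these differences acts.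

These compounds cannot separate the effect of closing the ring from the effect of losing the hydrogen on that nitrogen, a question that an open chain with a methyl group on the nitrogen could address. As far as these compounds go, it also remains open how far the tolerance extends, for instance to a longer chain, to a carboxylic acid in place of the amide, or to a piperazine ring without the carbonyl.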